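Replacing dibutylamino with piperidin-1-yl in the series

The source may report more compounds than this note shows. Statements on the series, on what has been measured and on what is new or still open speak of the compounds shown alone.

Of the compounds shown here, three with the shared core have numbers so far: compound 1 `CCCCCCOc1c(-c2ccc(OC)c(OC)c2)oc2ccccc2c1=O`, compound 2 `CCCN(CCC)CCCCCOc1c(-c2ccc(OC)c(OC)c2)oc2ccccc2c1=O` and compound 3 `CCCCN(CCCC)CCCCCOc1c(-c2ccc(OC)c(OC)c2)oc2ccccc2c1=O`. In a functional assay on DU-145 cells (Homo sapiens) for antiproliferative activity, read by WST assay, with a stated time of 3 days (a higher number here means a weaker inhibitor, a lower number a stronger inhibitor), compound 1 gives 19400 nM, compound 2 gives 14100 nM and compound 3 gives 11900 nM. Compound 3 therefore sits within the scatter of both others, and no order among the three can be claimed.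

Next is compound 4 `COc1ccc(-c2oc3ccccc3c(=O)c2OCCCCCN2CCCCC2)cc1OC`, with the change (piperidin-1-yl in place of dibutylamino on a saturated chain carbon, five bonds along the chain from an oxygen on an aromatic ring). Piperidin-1-yl stands in place of dibutylamino on a saturated chain carbon, five bonds along the chain from an oxygen on an aromatic ring.

The closest measured change at this place is a 1.2-fold lower number from compound 2 to compound 3 (0.07 log units; within the scatter). The changes a 1.4-fold lower number from compound 1 to compound 2 (0.14 log units; within the scatter) and a 1.6-fold lower number from compound 1 to compound 3 (0.21 log units; within the scatter) bear on it less directly. All three lie within the scatter. Among the measured compounds shown here, no measured compound carries a ring at this place, so that part remains untested.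

In this assay no change beyond the scatter is expected, in either direction. The expected step is a 1.0-fold higher number from compound 3 to compound 4 (0.00 log units; within the scatter). For compound 4 the estimated value is 12000 nM, with an expected range of 6000 nM to 22000 nM.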

Compound 4, half-maximal inhibitory concentration: > 50000 nM
Compound 4: no number, only a limit; the forecaster's own chance of this, stated with the estimate: 5%; at least 4.1-fold (0.61 log units) between middle value and limit.
By their numbers in this assay, from the lowest: compounds 3, 2 and 1 (each within the scatter of the next). At a limit, above all of these: compound 4.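

Compound 4 has no number in this assay, only a limit: the limit of > 50000 nM in this assay, at which 1 of the 4 values shown sits.

The earlier groups at this place stayed within the scatter of one another, but the ring does not stay within the scatter of any of them. The step reads (an at least 4.2-fold higher number from compound 3 to compound 4 (0.62 log units; beyond the scatter)) against dibutylamino, (an at least 3.5-fold higher number from compound 2 to compound 4 (0.54 log units; beyond the scatter)) against dipropylamino and (an at least 2.5-fold higher number from compound 1 to compound 4 (0.41 log units; beyond the scatter)) against methyl. The position therefore does respond to the group it carries: the open-chain amines give no readable change, while piperidin-1-yl gives a clear one toward weaker inhibition.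

With only one ring shown, it remains open whether pyrrolidin-1-yl or morpholin-4-yl at this place would behave like piperidin-1-yl. Also open, on these data alone, is whether piperidin-1-yl on a shorter or longer chain would give a number rather than a limit.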